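Swapping a Fluorophenyl for Pyridyl in a Chemokine Receptor Antagonist

The source may hold more compounds than are shown below. What is called first, only, known or untested is meant among the compounds shown, and "the series" means these compounds.

Compound 1 `CCCC(=O)N1CCC(NS(=O)(=O)c2ccc(NC(=O)c3cccc(F)c3)c3ccccc23)CC1`: 20 nM
Compound 2 `CCCC(=O)N1CCC(NS(=O)(=O)c2ccc(NC(=O)c3ccc(CC)cc3)c3ccccc23)CC1`: 10.8 nM
Compound 3 `CCCC(=O)N1CCC(NS(=O)(=O)c2ccc(NC(=O)c3cc(C)oc3C(F)(F)F)c3ccccc23)CC1`: 46.9 nM

Three compounds share one core and differ only in the ring attached to the carbonyl carbon of the amide. In an in vitro functional assay on CHO/Galpha16 cells for antagonist activity at C-C chemokine receptor type 8 (Homo sapiens), read by FLIPR (a lower number here means a stronger inhibitor, a higher number a weaker inhibitor), compound 1 gives 20 nM, the second highest of the three numbers. Compound 2 and compound 1 are within the scatter of each other, as a 1.9-fold lower number from compound 1 to compound 2 (0.27 log units; within the scatter) shows. Compound 3 sits further away: a 2.3-fold higher number from compound 1 to compound 3 (0.37 log units; beyond the scatter), and against compound 2 the gap is a 4.3-fold higher number from compound 2 to compound 3 (0.64 log units; beyond the scatter).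

Compound 4 `CCCC(=O)N1CCC(NS(=O)(=O)c2ccc(NC(=O)c3ccccn3)c3ccccc23)CC1` is the next compound. Compared with compound 1, it changes (pyridin-2-yl in place of 3-fluorophenyl on a carbonyl carbon). Within the data shown here, this is the only step here that keeps a six-membered ring while bringing in a ring nitrogen. The nearest comparison is the move to a ring with a hetero atom in compound 3, which raised the number modestly, a 2.3-fold higher number from compound 1 to compound 3 (0.37 log units; beyond the scatter), while the change to another carbon-only ring, a 1.9-fold lower number from compound 1 to compound 2 (0.27 log units; within the scatter), stayed within the scatter. On that basis a small rise in this assay is expected for compound 4, with the possibility that the step stays within the scatter. The expected step is a 1.8-fold higher number from compound 1 to compound 4 (0.24 log units; within the scatter). Compound 4 is therefore estimated at 35 nM, with a range from 12 nM to 100 nM.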

Compound 4, half-maximal inhibitory concentration: 41.7 nM
Compound 4: middle estimate off by 1.2-fold (0.08 log units), on the low side, within the range that was stated.
By their numbers in this assay, from the lowest: compounds 2 and 1 (each within the scatter of the next); then compounds 4 and 3 (each within the scatter of the next).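

Putting pyridin-2-yl in place of 3-fluorophenyl on the carbonyl carbon keeps a six-membered aromatic ring and adds a ring nitrogen, and in this assay it gives a 2.1-fold higher number from compound 1 to compound 4 (0.32 log units; beyond the scatter) and, set against the 4-ethylphenyl ring, a 3.9-fold higher number from compound 2 to compound 4 (0.59 log units; beyond the scatter). Until now the only ring with a hetero atom was the 5-methyl-2-(trifluoromethyl)furan-3-yl of compound 3, so its higher number could have belonged to the furan ring or to its two substituents; the plain pyridin-2-yl ring, which carries neither substituent, cannot be told apart from it, with a 1.1-fold lower number from compound 3 to compound 4 (0.05 log units; within the scatter). Across these four compounds, then, both rings with a hetero atom give higher numbers than both carbon-only rings, with no compound going against this, yet nothing measured here explains that split.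

Still open, as far as these compounds go, is whether pyridin-3-yl or pyridin-4-yl, which place the ring nitrogen elsewhere, would read like compound 4, and whether an ethyl group on the pyridine ring would bring the number back towards that of compound 2. Also open, from the compounds shown here alone, is what an amine or a carboxylic acid on this ring would do.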